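Notes on the step from compound 3 to compound 4

A few compounds are considered here, and "the series" means these few. Any claim that something is new, unique, unknown or untested is made for them only; others in the source may bear on it.

Measured so far in a functional assay on SNU-638 cells (Homo sapiens) for cytotoxicity, read by MTT assay; a lower number here means a stronger inhibitor, a higher number a weaker inhibitor:
- compound 1 `COc1ccc(C(=O)/C=C/c2ccc(F)cc2)c(O)c1` gives 18400 nM
- compound 2 `COc1cc(O)ccc1/C=C/C(=O)c1ccc(NC(C)=O)cc1` gives 17400 nM
- compound 3 `O=C(/C=C/c1ccc(F)cc1)c1ccc(O)cc1O` gives 9430 nM

Compound 3 stands within the scatter of both other compounds, so its value sets no order among the three. The next structure is compound 4 `COc1cc(O)ccc1C(=O)/C=C/c1ccc(F)cc1`, which differs from compound 3 in one place: methyl in place of hydrogen on an oxygen on an aromatic ring, or hydroxy to methoxy.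

Among the compounds with values here, one measured step bears on this change: a 2.0-fold lower number from compound 1 to compound 3 (0.29 log units; within the scatter), with hydrogen in place of methyl on an oxygen on an aromatic ring. This is the same kind of exchange, run the other way. The structures show that compound 1 and compound 4 carry their methyl on different oxygens, so the guidance is limited. Within the data shown here, compound 2 offers no single-place step to compare.

Read in reverse, the measured step suggests a slightly higher number in this assay, and nothing beyond the scatter is expected. The expected change is a 1.5-fold higher number from compound 3 to compound 4 (0.17 log units; within the scatter) in this estimate. For compound 4 the estimated value is 14000 nM, with an expected range of 6500 nM to 30000 nM.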

Compound 4, half-maximal inhibitory concentration: > 25000 nM
Compound 4 was reported as a limit (the forecaster's own chance of this, stated with the estimate: 8%); middle value at least 1.7-fold (0.25 log units) away from the limit.
By their numbers in this assay, from the lowest: compounds 3, 2 and 1 (each within the scatter of the next). At a limit, above all of these: compound 4.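

In this assay, within the data shown here, hydrogen to methyl on this oxygen gives an at least 2.6-fold higher number from compound 3 to compound 4 (0.42 log units; beyond the scatter), the first step to lie beyond the scatter. The corresponding exchange on a different oxygen, a 2.0-fold lower number from compound 1 to compound 3 (0.29 log units; within the scatter), stays within the scatter, so the two oxygens of compound 3 do not respond alike to this change in the compounds shown. Compound 4 stands as a limit, so its step fixes only a lower bound on the change and gives no actual size: the limit of > 25000 nM in this assay, at which 1 of the 4 values shown sits.

The compounds shown hold only hydrogen and methyl on this oxygen, so it remains open how the number in this assay responds to a longer chain, such as ethyl, or to a chain ending in an amine. Also open, going by these compounds, is whether the same step appears when the fluorine of compound 3 gives way to another group; compound 2 has no single-place partner among the four compounds and offers no guidance on that.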